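The compounds below may be only part of what the source reports. "The series", "measured", "known", "first", "only" and "open" are said of these compounds alone.

Compound 1, with the structure `Nc1n[n+]([O-])c2c(Cl)cccc2[n+]1[O-]`, gives in a physicochemical assay for lipophilicity (on this read-out higher numbers stand for higher lipophilicity and lower numbers for lower lipophilicity), a value of 0.17. Compound 2, with the structure `Nc1n[n+]([O-])c2c(C(F)(F)F)cccc2[n+]1[O-]`, gives in this assay a value of 0.53. The two differ by one change, (trifluoromethyl in place of chloro on an aromatic carbon), and the measured step is a number 0.36 log units higher from compound 1 to compound 2 (beyond the scatter). Compound 3, with the structure `Nc1n[n+]([O-])c2cc(Cl)ccc2[n+]1[O-]`, gives in this assay a value of 0.44. Compound 3 has the same atoms as compound 1 joined differently; the difference between the two cores is not broken down here.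

Compound 4, with the structure `Nc1n[n+]([O-])c2cc(C(F)(F)F)ccc2[n+]1[O-]`, has not yet been measured in this assay. It is related to compound 3 by trifluoromethyl in place of chloro on an aromatic carbon. Within the data shown here, this is the same kind of change as the one from compound 1 to compound 2, but the surroundings are not identical: in compound 1 the carbon that carries the group is ortho to a fused ring and meta to a fused ring, whereas in compound 3 it is meta to a fused ring and para to a fused ring.

Compound 4 is expected to lie a step of a number 0.36 log units higher from compound 3 to compound 4 (beyond the scatter) from compound 3. Among the measured compounds shown here, this expectation rests on the earlier measured step of a number 0.36 log units higher from compound 1 to compound 2 (beyond the scatter), since only that one pair shows the change. Compound 4 is therefore estimated to come out near 0.8, with a likely range from 0.55 to 1.05.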

Compound 4, partition coefficient: 0.81
Beside the measured number, compound 4's estimate is 0.01 log units below it; low and high end bracket the measured number.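

In this assay the change from chloro to trifluoromethyl gives a number 0.37 log units higher from compound 3 to compound 4 (beyond the scatter) and so matches, in direction and closely in size, the earlier a number 0.36 log units higher from compound 1 to compound 2 (beyond the scatter) on the core of compound 1. The change therefore carried over from that core to the core of compound 3 in this one instance, but two pairs do not show that the step would hold on further cores, at other places on the aromatic ring, or for any other exchange of groups. Nothing available here bears on why the step has this size on either core, and the agreement between the two pairs remains an observation without an explanation.

The compounds shown leave open how a nitrile, a carboxylic acid, a methoxy group or a longer alkyl chain in the same place would read in this assay on either core. They also leave open whether the step seen with trifluoromethyl in place of chloro would keep its size if the amine on the shared core were replaced by another group.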